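Cutting the side chain of compound 1: what to expect

The compounds below may be only part of what the source reports. "The series", "measured", "known", "first", "only" and "open" are said of these compounds alone.

The three measured compounds share one core and differ in the amino-acid part attached through the amide. Compound 1 `O=C(CN(c1nc(Cl)nc2[nH]cnc12)C1CC1)N[C@@H](CC(=O)OCc1ccccc1)C(=O)OCc1ccccc1` is the dibenzyl ester of an aspartate; compound 2 `O=C(OCc1ccccc1)[C@@H]1CCCN1C(=O)CN(c1nc(Cl)nc2[nH]cnc12)C1CC1` carries a proline benzyl ester; compound 3 `C[C@@H](O)[C@H](NC(=O)CN(c1nc(Cl)nc2[nH]cnc12)C1CC1)C(=O)O` carries a free threonine acid. In a functional assay on the whole organism (Tail, strain ICR) with Mus musculus as the target, in the tail flick test, with a stated time of 120 min, at a dose of 25 umol/kg by the oral route (a higher number here means a stronger effect of the compound at the dose given, a lower number a weaker effect), compound 1 gives 12.1%, the lowest of the three numbers. Compound 2 gives 38.4% and compound 3 gives 37.6% in this assay, both beyond the scatter above compound 1, while compound 2 and compound 3 lie within the scatter of each other.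

Compound 4 `O=C(CN(c1nc(Cl)nc2[nH]cnc12)C1CC1)NCC(=O)OCc1ccccc1` follows from compound 1 by one change: hydrogen in place of (benzyloxycarbonyl)methyl on a saturated chain carbon bound to an amide-type nitrogen and a carbonyl carbon. The amide, the ester and the whole core stay the same; only the (benzyloxycarbonyl)methyl group is lost, leaving a glycine benzyl ester.

Among the measured compounds shown here, no step between two measured compounds matches this change, so the size of the expected step is uncertain. Given that the two smaller amino-acid parts of compound 2 and compound 3 sit well above compound 1, a moderate rise in this assay is expected from compound 1 to compound 4, estimated as a number 12.9 percentage points higher from compound 1 to compound 4 (beyond the scatter). For compound 4 the expected activity in this assay is 25%, with a range from 8% to 45%.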

Compound 4, a percentage reported as activity, at one dose (the size of the read-out at that dose, not a potency): 21.7%
The estimate for compound 4 lay 3.3 percentage points above the measured number; the measured number falls inside the stated range.
By their numbers in this assay, from the lowest: compounds 1 and 4 (each within the scatter of the next); then compounds 3 and 2 (each within the scatter of the next).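

Taking away the (benzyloxycarbonyl)methyl group gave the first direct reading of this position on the saturated chain carbon bound to an amide-type nitrogen and a carbonyl carbon: in this assay the change amounts to a number 9.6 percentage points higher from compound 1 to compound 4 (within the scatter) and so does not separate the two compounds. A group of 11 heavy atoms, including a six-membered aromatic ring of carbon only, can therefore be replaced by hydrogen with no change beyond the scatter, at this one dose and time, while the amide, the remaining benzyl ester and the shared core stay in place. Nothing shown explains why this read-out stays within the scatter after so large a group is lost.

Going by these compounds, what a small group such as methyl, or a side chain ending in a free carboxylic acid or an amine, would give on this same carbon remains open. On these data alone, it also remains open whether a longer chain there would keep the read-out within the scatter of compound 1 and compound 4 or move it beyond, and whether the same holds at other doses or times.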